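The compounds below may be only part of what the source reports. "The series", "measured", "known", "first", "only" and "open" are said of these compounds alone.

Compound 1 `CC1=C(C(=O)Nc2cccc(Cl)c2)C(c2cnc(CS)n2Nc2ccccc2)NC(=O)N1` gives 98600 nM in an ADME assay on Vero cells (Chlorocebus sabaeus) for cytotoxicity, read by XTT assay, with a stated time of 72 h; a higher number here means that more compound is tolerated, a lower number that less compound is tolerated. Compound 2 `CC1=C(C(=O)Nc2ccccc2Cl)C(c2cnc(CS)n2NCc2ccccc2)NC(=O)N1` reaches only the limit of this assay, > 100000 nM. Compound 3 `CC1=C(C(=O)Nc2cccc(Cl)c2)C(c2cnc(CS)n2NCc2ccccc2)NC(=O)N1` likewise gives only the limit, > 100000 nM. The step of an at least 1.0-fold higher number from compound 1 to compound 3 (0.00 log units; that floor lies within the scatter) therefore sits at the floor, and the step that the two limits leave unreadable from compound 2 to compound 3 cannot be read, owing to the limit of > 100000 nM in this assay, at which 2 of the 3 values shown sit. Compound 4 `CCOC(=O)C1=C(C)NC(=O)NC1c1cnc(CS)n1NCc1ccccc1` differs from compound 3 by ethoxy in place of (3-chlorophenyl)amino on a carbonyl carbon. Among the measured compounds shown here, no measured step touches the carbonyl substituent, so the expectation rests on the three values alone, all of which sit at or close to the limit. The step of a number no higher from compound 3 to compound 4 (the limit leaves the size open) is expected to lie within the scatter. Compound 4 is estimated at 100000 nM, between 50000 nM and 200000 nM.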

Compound 4, half-maximal cytotoxic concentration: "non-toxic" (no number reported)
For compound 4 the study gives words and no number; the estimate stays without a comparison.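

Among the compounds shown here, compound 4 is reported in this assay only as "non-toxic", without a number, so no new step from compound 3 to compound 4 can be read. The compounds shown leave open how ethoxy and (3-chlorophenyl)amino on the carbonyl carbon compare, with the values resting on this: the limit of > 100000 nM in this assay, at which 2 of the 4 values shown sit.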